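Acyl variation on the shared core: oxolanyl in place of methylcyclobutyl

The source may report more compounds than this note shows. Statements on the series, on what has been measured and on what is new or still open speak of the compounds shown alone.

Going by the values given here, in an assay on HEK293 cells for positive allosteric modulation of metabotropic glutamate receptor 5 (Homo sapiens), read by FLIPR, with a stated time of 1 h (on this read-out lower numbers stand for an effect already at smaller amounts and higher numbers for an effect only at larger amounts of compound), compound 3 `CC1CC(C(=O)N2CCc3nc(C#Cc4ccccc4)sc3C2)C1` gives 81 nM, the only number among the three values shown. Compound 1 `O=C(C1CC1)N1CCc2nc(C#Cc3ccccc3)sc2C1` sits at the limit of > 10000 nM, which is a limit of the assay and not a number. Compound 2 `O=C(C1CCC1)N1CCc2nc(C#Cc3ccccc3)sc2C1` likewise sits at > 10000 nM, again a limit. Both share (the limit of > 10000 nM in this assay, at which 2 of the 3 values shown sit).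

Compound 4 `O=C(C1CCCO1)N1CCc2nc(C#Cc3ccccc3)sc2C1` differs from compound 3 by oxolan-2-yl in place of 3-methylcyclobutyl on a carbonyl carbon. Among the compounds with values here, two measured steps bear on this position. The step of an at least 120-fold lower number from compound 1 to compound 3 (2.09 log units; beyond the scatter) and the step of an at least 120-fold lower number from compound 2 to compound 3 (2.09 log units; beyond the scatter) both show that the 3-methylcyclobutyl group carries the whole measurable gain, while the unmethylated cyclobutyl and cyclopropyl groups give only limits. Within the data shown here, compound 4 removes the methyl and the all-carbon four-membered ring at once and brings a five-membered ring with one oxygen, which no measured compound shares.

A large rise in this assay is therefore expected, with a fair chance that compound 4 reaches only a limit. Compound 4 is estimated at 5000 nM, within 1000 nM to 30000 nM, which corresponds to an expected step of a 62-fold higher number from compound 3 to compound 4 (1.79 log units; beyond the scatter).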

Compound 4, half-maximal effective concentration: 790 nM
Compound 4: the middle estimate sits 6.3-fold (0.80 log units) above what was measured, outside the stated range (below it).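

In this assay, going by these compounds alone, 3-methylcyclobutyl is no longer the only group on this carbonyl carbon to give a number, as oxolan-2-yl also does (an at least 12-fold lower number from compound 2 to compound 4 (1.10 log units; beyond the scatter); an at least 12-fold lower number from compound 1 to compound 4 (1.10 log units; beyond the scatter)). Even so, the methylated all-carbon ring of compound 3 keeps the lower number, so exchanging it for oxolan-2-yl gives up part of the gain (a 9.8-fold higher number from compound 3 to compound 4 (0.99 log units; beyond the scatter)). The two steps from compound 1 and compound 2 start from limits of the assay, not numbers, so they give only a minimum size: the limit of > 10000 nM in this assay, at which 2 of the 4 values shown sit.

The compounds shown do not separate the ring size from the ring oxygen, since compound 3 and compound 4 differ in both at once. On these data alone, how cyclopentyl, oxetan-2-yl or oxolan-3-yl would read on this carbonyl carbon stays open, as does the effect of a methyl on the oxolane ring.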